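This account rests on a few compounds, and the source may have more. Where it says the series, first, only, none or still open, it means among the compounds named here.

Among the compounds with values here, only two compounds in this small series have been measured so far. In an ADME assay for permeability, using PAMPA, with a stated time of 3 h (on this read-out higher numbers stand for higher permeability and lower numbers for lower permeability), compound 1 (`O=C(Nc1ccc([N+](=O)[O-])cc1)c1cc(Cl)ccc1O`) gives 12.4 10^-6 cm/s and compound 2 (`O=C(Nc1cccc([N+](=O)[O-])c1)c1cc(Cl)ccc1O`) gives 19.5 10^-6 cm/s on the same scale. These two numbers lie within the usual scatter of repeated measurements, so compound 1 stands level with compound 2 on the present evidence.

The unmeasured compound 3 (`O=C(Nc1ccc([N+](=O)[O-])c(Cl)c1)c1cc(Cl)ccc1O`) comes from compound 1 through a single structural change (chloro in place of hydrogen on an aromatic carbon): chloro in place of hydrogen on an aromatic carbon, ortho to a nitro group and meta to a large group. Within the data shown here, no pair of measured compounds shows what such a change does in this assay and this leaves little to go on. The expectation therefore starts from compound 1 at 12.4 10^-6 cm/s and allows only a slight rise, with no step beyond the scatter. The estimated change is a 1.2-fold higher number from compound 1 to compound 3 (0.08 log units; within the scatter) and it is expected to stay within that scatter. For compound 3 the expected value is 15 10^-6 cm/s with an estimated range from 6 10^-6 cm/s to 35 10^-6 cm/s on this read-out.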

Compound 3, apparent permeability: 12.3 10^-6 cm/s
For compound 3 the middle estimate is 1.2-fold (0.09 log units) above the measured one; low and high end bracket the measured number.
By their numbers in this assay, from the lowest: compounds 3, 1 and 2 (each within the scatter of the next).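

Within the data shown here, compound 1 and compound 3 are the first pair that differ in one place, so this position now has a direct reading in this assay. Putting chloro in place of hydrogen on an aromatic carbon, ortho to a nitro group and meta to a large group, gives a 1.0-fold lower number from compound 1 to compound 3 (0.00 log units; within the scatter), which means that the two compounds stand level on this read-out and that one extra chlorine atom at this position is tolerated on the core of compound 1. Nothing measured here goes beyond those numbers to explain why they stand level.

This is still a single pair on a single core, so whether chloro in place of hydrogen would read the same way on the core of compound 2 remains an open question. Also open, on these data alone, is whether a different group at this same position, such as a methyl group, an amine or a carboxylic acid, would stay level with compound 1 or would move the number beyond the scatter.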